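From piperidinyl to ethyl(4-fluorobenzyl)amino: an expected gain

The source may hold more compounds than are shown below. What is called first, only, known or untested is meant among the compounds shown, and "the series" means these compounds.

Compound 3 `NS(=O)(=O)Oc1ccc2c(c1)CN(C(=O)c1ccc(N3CCCCC3)cc1)CC2` gives 11.5% in an assay on HEK293 cells for inhibition of Steryl-sulfatase (Homo sapiens), tested at 0.1 uM (a lower number here means a weaker effect, a higher number a stronger effect of the compound at the concentration tested), the lowest of the three measured numbers. Compound 1 `CC(C)CCN(CCC(C)C)c1ccc(C(=O)N2CCc3ccc(OS(N)(=O)=O)cc3C2)cc1` gives 47%, and compound 2 `CCN(Cc1ccc(Br)cc1)c1ccc(C(=O)N2CCc3ccc(OS(N)(=O)=O)cc3C2)cc1` gives 78.2%. Compound 4 `CCN(Cc1ccc(F)cc1)c1ccc(C(=O)N2CCc3ccc(OS(N)(=O)=O)cc3C2)cc1` differs from compound 3 by ethyl(4-fluorobenzyl)amino in place of piperidin-1-yl on an aromatic carbon. The most telling comparison is the step of a number 66.7 percentage points lower from compound 2 to compound 3 (beyond the scatter), where the same piperidin-1-yl arrived in place of a closely related (4-bromobenzyl)(ethyl)amino group; the step of a number 35.5 percentage points lower from compound 1 to compound 3 (beyond the scatter) points the same way. Reversing that exchange, now with fluorine rather than bromine on the benzyl group, should therefore bring a large rise, although the two halogens have not been compared directly here. Compound 4 is expected to give 68% (range 45% to 85%). The expected step is a number 56.5 percentage points higher from compound 3 to compound 4 (beyond the scatter).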

Compound 4, a percentage reported as inhibition, at one concentration (the size of the read-out at that concentration, not a potency): 69.1%
Estimate against measurement, compound 4: 1.1 percentage points below; low and high end bracket the measured number.
By their numbers in this assay, from the lowest: compound 3; then compound 1; then compounds 4 and 2 (each within the scatter of the next).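

Fluoro and bromo on the benzyl ring cannot be told apart in this assay, which shows a number 9.1 percentage points lower from compound 2 to compound 4 (within the scatter). The large rise over piperidin-1-yl therefore holds with either halogen, at a number 57.6 percentage points higher from compound 3 to compound 4 (beyond the scatter), and the fluorinated group also leads to a number 22.1 percentage points higher from compound 1 to compound 4 (beyond the scatter), a more modest gain over diisopentylamino. Nothing available explains these differences.

Going by these compounds, it remains open what an unsubstituted benzyl group, or a methoxy group in place of the halogen, would give. On these data alone, whether a propyl chain could replace the ethyl group and keep the read-out is also open.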